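Bombesin receptor subtype-3 agonists: aliphatic versus aryl methylene substituent

A few compounds are considered here, and "the series" means these few. Any claim that something is new, unique, unknown or untested is made for them only; others in the source may bear on it.

Measured so far:
compound 1, `O=C(O)c1ccccc1-c1ccc(CCc2ncc(CC3CCCCC3)[nH]2)cc1`, 41 nM
compound 2, `CC(C)(C)CCc1cnc(CCc2ccc(-c3ccccc3C(=O)O)cc2)[nH]1`, 39 nM
compound 3, `COc1ccccc1Cc1cnc(CCc2ccc(-c3ccccc3C(=O)O)cc2)[nH]1`, 1720 nM

In an in vitro functional assay on cells for agonist activity at Bombesin receptor subtype-3 (Homo sapiens), read by luminescence and calcium flux (on this read-out lower numbers stand for an effect already at smaller amounts and higher numbers for an effect only at larger amounts of compound), compound 3 stands at the highest number of the three. The steps to it from the two aliphatic analogues are both large: a 42-fold higher number from compound 1 to compound 3 (1.62 log units; beyond the scatter) and a 44-fold higher number from compound 2 to compound 3 (1.64 log units; beyond the scatter), while a 1.1-fold lower number from compound 1 to compound 2 (0.02 log units; within the scatter) stays within the scatter. Compound 4, `CC(C)(C)Cc1cnc(CCc2ccc(-c3ccccc3C(=O)O)cc2)[nH]1`, is derived from compound 3 by the change (tert-butyl in place of 2-methoxyphenyl on a saturated chain carbon bound to an aromatic carbon); cut one bond further out, the same difference reads 2-methoxybenzyl to neopentyl. The two steps that bear on it, from compound 1 and from compound 2 to compound 3, both show that replacing a group with no ring by 2-methoxyphenyl at this saturated chain carbon raises the number strongly, so the reverse direction should lower it strongly. The tert-butyl group has no ring, as cyclohexyl and neopentyl have none, but it is not the same group, so the full return to the level of compound 1 and compound 2 is not assured. The expected step is a 22-fold lower number from compound 3 to compound 4 (1.33 log units; beyond the scatter), a large decrease in number. Compound 4 is therefore estimated at 80 nM, with a range from 25 nM to 300 nM in this assay.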

Compound 4, half-maximal effective concentration: 106 nM
Compound 4: the middle estimate sits 1.3-fold (0.12 log units) below what was measured; the measured number falls inside the stated range.
By their numbers in this assay, from the lowest: compounds 2 and 1 (each within the scatter of the next); then compound 4; then compound 3.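

In this assay, for the compounds shown here, the earlier steps ran only towards 2-methoxyphenyl; the reverse step, tert-butyl in place of 2-methoxyphenyl on this saturated chain carbon, also proves large (a 16-fold lower number from compound 3 to compound 4 (1.21 log units; beyond the scatter)), so the high number of compound 3 is not specific to the comparison with cyclohexyl or neopentyl. Groups without an aromatic ring are not fully interchangeable here, although compound 1 and compound 2 lie within the scatter of each other: the tert-butyl group leaves modest gaps beyond the scatter (a 2.7-fold higher number from compound 2 to compound 4 (0.43 log units; beyond the scatter); a 2.6-fold higher number from compound 1 to compound 4 (0.41 log units; beyond the scatter)). No supporting data bear on these differences.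

Whether the high number of compound 3 follows the phenyl ring itself or its methoxy group remains open, with plain phenyl absent from the compounds shown. From the compounds shown here alone, how an amine or a carboxylic acid at the end of a longer chain would fare at this carbon also remains open.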